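A few compounds are considered here, and "the series" means these few. Any claim that something is new, unique, unknown or untested is made for them only; others in the source may bear on it.

Working notes on the oxazole ketone series. The shared core of compound 1 `CC(C)(C)CC(=O)N1CCC(CCCC(=O)c2ncco2)CC1` carries a neopentylcarbonyl on the ring nitrogen; in an assay on isolated protein for inhibition of Fatty-acid amide hydrolase 1 (Homo sapiens) (a higher number here means a weaker inhibitor, a lower number a stronger inhibitor), compound 1 gives 90 nM. Compound 2 `Cc1ccc(CN2CCC(CCCC(=O)c3ncco3)CC2)cc1` replaces it with a 4-methylbenzyl, and compound 2 gives 400 nM; this is a 4.4-fold higher number from compound 1 to compound 2 (0.65 log units; beyond the scatter). Compound 3 `COc1cccc(CN2CCC(CCCC(=O)c3ncco3)CC2)c1` carries a 3-methoxybenzyl instead, and compound 3 gives 34 nM, a change of a 12-fold lower number from compound 2 to compound 3 (1.07 log units; beyond the scatter). Among the three numbers compound 2 stands highest, so it is the weakest inhibitor shown; compound 1 sits nearer to it and compound 3 furthest away.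

Compound 4 `CC(C)Oc1ccc(CN2CCC(CCCC(=O)c3ncco3)CC2)cc1` is the next step from compound 2: isopropoxy in place of methyl on an aromatic carbon. Going by the values given here, the step most relevant to it is the one from compound 2 to compound 3, where an alkoxy group entered the benzyl ring and the number fell sharply, though that step also shifted the group to another aromatic carbon, so it bears on compound 4 only in part. The step from compound 1 to compound 2 concerns the nitrogen substituent and says nothing direct about the aryl group. Because the step to compound 3 was a 12-fold lower number from compound 2 to compound 3 (1.07 log units; beyond the scatter), a lower number than compound 2 is expected for compound 4, most likely of modest to large size rather than nothing beyond the scatter. The estimate for compound 4 is 110 nM, within 35 nM to 350 nM, meaning an expected step of a 3.6-fold lower number from compound 2 to compound 4 (0.56 log units; beyond the scatter).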

Compound 4, half-maximal inhibitory concentration: 14 nM
Compound 4: middle estimate off by 7.9-fold (0.90 log units), on the high side; measured number outside the range, below it.
By their numbers in this assay, from the lowest: compound 4; then compound 3; then compound 1; then compound 2.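

On the aromatic carbon para to a large group, the change from methyl to isopropoxy gives a 29-fold lower number from compound 2 to compound 4 (1.46 log units; beyond the scatter) in this assay and so shows that this position responds strongly to the group it carries. Going by these compounds alone, compound 3 differs from compound 2 in both the alkoxy group and its place on the ring, so it could not show this; here the place is held and only the group changes, which makes this the first step that reads the effect at this carbon on its own. Nothing at hand accounts for the size of this step.

On these data alone, the entering isopropoxy brings both an oxygen and more carbon than the methyl, so it remains open whether the oxygen or the added carbon carries the step, a question that methoxy and ethyl at the same aromatic carbon would address. Also open, as far as these compounds go, is how far this position tolerates other groups, such as a cyclopentyloxy, an amine or a carboxylic acid, and whether isopropoxy behaves alike on the aromatic carbon that holds the methoxy of compound 3.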